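Ethyl in Place of Ethoxy on the Core of Compound 2

A few compounds are considered here, and "the series" means these few. Any claim that something is new, unique, unknown or untested is made for them only; others in the source may bear on it.

For the measured compounds named here, compound 2 `CCOc1cnc(N2CCC([C@H]3C[C@H]3COCc3ccc(S(C)(=O)=O)c(F)c3)CC2)nc1` and compound 1 `COc1cnc(N2CCC([C@H]3C[C@H]3COCc3ccc(S(C)(=O)=O)cc3F)CC2)nc1` share the same core but differ in more than one place, so no single step connects them. In a functional assay on isolated protein for agonist activity at Glucose-dependent insulinotropic receptor (Mus musculus), read by cAMP accumulation (on this read-out lower numbers stand for an effect already at smaller amounts and higher numbers for an effect only at larger amounts of compound), compound 2 gives 2.3 nM. In this assay compound 1 gives 1.4 nM. Going by the values given here, the gap between these two numbers lies within the usual scatter of repeated measurements, so the two compounds cannot be told apart on this read-out, and compound 2 stands at the same level as its only neighbour.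

Compound 3 `CCc1cnc(N2CCC([C@H]3C[C@H]3COCc3ccc(S(C)(=O)=O)c(F)c3)CC2)nc1` has not yet been measured. It differs from compound 2 in one place: ethyl in place of ethoxy on an aromatic carbon, an ethyl in place of ethoxy on an aromatic carbon. Among the compounds with values here, no measured pair shows what this exchange does, so the expected size of the step in this assay rests only on the two numbers at hand. A modest move toward larger amounts seems the most likely outcome, though a step that stays within the scatter cannot be excluded. Compound 3 is expected to give 4.5 nM, within a range from 1.3 nM to 15 nM. The step from compound 2 to compound 3 that this estimate means is a 2.0-fold higher number from compound 2 to compound 3 (0.29 log units; within the scatter), expected rather than measured.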

Compound 3, half-maximal effective concentration in the Glucose-dependent insulinotropic receptor assay: 5.5 nM
The estimate for compound 3 lay 1.2-fold (0.09 log units) below the measured number, within the range that was stated.
By their numbers in the Glucose-dependent insulinotropic receptor assay, from the lowest: compounds 1 and 2 (each within the scatter of the next); then compound 3.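

In the Glucose-dependent insulinotropic receptor assay, compound 2 gives 2.3 nM and compound 3 gives 5.5 nM and the exchange of 5-ethoxypyrimidin-2-yl for 5-ethylpyrimidin-2-yl gives a 2.4-fold higher number from compound 2 to compound 3 (0.38 log units; beyond the scatter), the first single-place step available here, and it shows that this aromatic carbon, para to a large group, responds to the change, though only modestly. For the compounds shown here, in a physicochemical assay for solubility, in simulated intestinal fluid, measured as kinetic solubility, at pH 6.5 (on this read-out higher numbers stand for higher solubility and lower numbers for lower solubility), compound 2 gives 101000 nM and compound 3 gives 140000 nM and the same exchange gives a 1.4-fold higher number from compound 2 to compound 3 (0.14 log units; within the scatter), so on that read-out compound 2 and compound 3 cannot be told apart, and the step seen in the receptor read-out has no counterpart there. The ethoxy group carries one hydrogen-bond acceptor and the ethyl group none, but no measurement available here connects that difference to the step, and nothing shown accounts for its cause.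

With only one exchange at this position, the compounds shown leave open how other groups would behave there, such as a propyl chain, a nitrile or an amine. They also leave open whether ethyl in place of ethoxy would give a step of the same size on the core of compound 1, which differs from compound 2 in more than one place.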